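Compound 3: vinylcarbonyl on the ring amine nitrogen

The source may hold more compounds than are shown below. What is called first, only, known or untested is meant among the compounds shown, and "the series" means these compounds.

In a functional assay on MCF7 cells (Homo sapiens) for antiproliferative activity, read by CCK-8 assay, with a stated time of 48 h (on this read-out lower numbers stand for stronger inhibition and higher numbers for weaker inhibition), compound 2 `O=C(/C=C/CN1CC(Oc2ccc(Oc3c(-c4ccc(F)cc4)sc4cc(O)ccc34)cc2)C1)N1CCC1` gives > 25000 nM, which is a limit and not a number. Compound 1 `CNC(=O)/C=C/CN1CC(Oc2ccc(Oc3c(-c4ccc(F)cc4)sc4cc(O)ccc34)cc2)C1` gives > 25000 nM, which is also a limit. Going by the values given here, the series so far therefore amounts to the limit of > 25000 nM in this assay, at which 2 of the 2 values shown sit, and it holds no exact number.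

Compound 3 `C=CC(=O)N1CC(Oc2ccc(Oc3c(-c4ccc(F)cc4)sc4cc(O)ccc34)cc2)C1` keeps the shared core and alters the group on an amine nitrogen in a ring, a four-membered non-aromatic ring with 1 nitrogen: vinylcarbonyl in place of 3-((azetidin-1-yl)carbonyl)prop-2-en-1-yl on an amine nitrogen in a ring.

Among the compounds with values here, only one measured step bears on this change. It is a step that the two limits leave unreadable from compound 1 to compound 2, made by azetidin-1-yl in place of methylamino on a carbonyl carbon. It offers no size to carry over, so the expectation rests on the structural change alone, and it is a loose one.

The estimated step in this assay is an at least 1.6-fold lower number from compound 2 to compound 3 (0.22 log units; that floor lies within the scatter), expected to run toward stronger inhibition, although the reading may well stay a limit. For compound 3 the expected value is 15000 nM, with an estimated range of 3000 nM to 40000 nM.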

Compound 3, half-maximal inhibitory concentration: 23500 nM
Beside the measured number, compound 3's estimate is 1.6-fold (0.19 log units) below it; measured number inside the range.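

In this assay, going by these compounds alone, compound 3 gives the first exact number of the series, so vinylcarbonyl on the amine nitrogen in the ring brings the reading just inside the measurable range. As far as these compounds go, the change reads as an at least 1.0-fold lower number from compound 2 to compound 3 (0.02 log units; that floor lies within the scatter), and the change that replaces 3-(methylcarbamoyl)prop-2-en-1-yl reads as an at least 1.0-fold lower number from compound 1 to compound 3 (0.02 log units; that floor lies within the scatter); as printed, both floors lie within the scatter, so neither establishes a real gain, and the true size of each step stays unknown. Removing either longer group therefore gives no more than a reading at the edge of the limit that still marks the other two compounds: the limit of > 25000 nM in this assay, at which 2 of the 3 values shown sit.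

From the compounds shown here alone, how much of the reading of compound 3 belongs to the double bonds of vinylcarbonyl, rather than to the loss of the longer chain, remains open, and a propanoyl group on the same nitrogen would speak to that. Also open, going by these compounds, is whether any group on this nitrogen, such as a dimethylamino group at the end of the butenoyl chain, would bring the reading clearly below the limit.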